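The compounds below may be only part of what the source reports. "The series", "measured", "known", "first", "only" and "open" are said of these compounds alone.

Working notes on a series of arylacetylene propanoic acids tested in an in vitro functional assay on 1321-N1 cells for agonist activity at Free fatty acid receptor 1 (Homo sapiens), read by fluorescence, spectrophotometry and calcium flux; on this read-out higher numbers stand for an effect only at larger amounts of compound and lower numbers for an effect already at smaller amounts.

Compound 1 `O=C(O)CCc1ccc(C#Cc2ccnc(Cl)c2)cc1` gives 295 nM in this assay. Compound 3 `O=C(O)CCc1ccc(C#Cc2cc(Cl)nc(Cl)c2)cc1`, the dichloro analogue, gives 40.7 nM. The step is a 7.2-fold lower number from compound 1 to compound 3 (0.86 log units; beyond the scatter), the change being (chloro in place of hydrogen on an aromatic carbon). Compound 2 `O=C(O)CCc1ccc(C#Cc2cccnc2)cc1`, whose core carries the ring nitrogen in a different relation to the acetylene, gives 6030 nM; how the two cores of compound 1 and compound 2 differ is not broken down here, and the values alone show compound 2 standing highest of the three.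

Compound 4 `O=C(O)CCc1ccc(C#Cc2cccnc2Cl)cc1` has not yet been measured. It differs from compound 2 by chloro in place of hydrogen on an aromatic carbon. This is the same kind of change as from compound 1 to compound 3, not the same: in compound 4 the new chloro sits next to the ring nitrogen and ortho to a large group, whereas in compound 3 it sits next to the ring nitrogen, meta to a chloro group and meta to a large group.

Going by the values given here, for compound 4 in this assay the expected step is a 4.0-fold lower number from compound 2 to compound 4 (0.60 log units; beyond the scatter), resting on the single measured step of this kind, a 7.2-fold lower number from compound 1 to compound 3 (0.86 log units; beyond the scatter). The surroundings of the place are not the same, so the expected step is kept smaller than that one. Compound 4 is thus estimated at 1500 nM, between 500 nM and 5000 nM.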

Compound 4, half-maximal effective concentration: 603 nM
The estimate for compound 4 lay 2.5-fold (0.40 log units) above the measured number; measured number inside the range.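

In this assay, chloro in place of hydrogen on an aromatic carbon gives a 10-fold lower number from compound 2 to compound 4 (1.00 log units; beyond the scatter). Set beside the same change on the other core, the size of the step carries over: the same change on two cores in this assay, a 7.2-fold lower number (0.86 log units; beyond the scatter) from compound 1 to compound 3 and a 10-fold lower number (1.00 log units; beyond the scatter) from compound 2 to compound 4, 1.4-fold (0.14 log units) apart, within the scatter of two such steps

Going by these compounds alone, this rests on only two steps on two cores, with the new chloro in different surroundings in each, so it supports carrying the change between these two cores but gives no general rule for the series and no explanation of why the steps agree.

Going by these compounds, it remains open whether fluoro, methyl, nitrile or an amine in the same place would give a step of similar size to chloro. On these data alone, it also remains open whether the chloro step would hold if the propanoic acid were replaced by a longer chain.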